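A Larger Aromatic Arm in Place of a Small Nitrogen Group

This account rests on a few compounds, and the source may have more. Where it says the series, first, only, none or still open, it means among the compounds named here.

The three compounds measured so far, all tested in a functional assay, read by spectrophotometry, with a stated time of 5 min; on this read-out lower numbers stand for stronger inhibition and higher numbers for weaker inhibition:

Compound 1 `Nc1ccccc1/N=C\c1cc(=O)oc2cc(OCc3ccccc3)ccc12` gives 217000 nM.
Compound 2 `O=c1cc(/C=N\O)c2ccc(OCc3ccccc3)cc2o1` gives > 2000000 nM; this is a limit of the assay, not a number (the limit of > 2000000 nM in this assay, at which 1 of the 3 values shown sits).
Compound 3 `N/N=C\c1cc(=O)oc2cc(OCc3ccccc3)ccc12` gives 131000 nM.

All three share one core and differ only in the group hanging from the double-bonded nitrogen on that core. Compound 3 sits lowest of the two real numbers in this assay, though its nearest neighbour, compound 1, is close: the change a 1.7-fold lower number from compound 1 to compound 3 (0.22 log units; within the scatter) stays within the usual scatter. The step from the hydroxy compound is a different matter: an at least 15-fold lower number from compound 2 to compound 3 (1.18 log units; beyond the scatter) is large, so the amino group clearly works better than the hydroxy group here.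

Compound 4 `O=c1cc(-c2nc3ccccc3[nH]2)c2ccc(OCc3ccccc3)cc2o1` is the next step. The change is a group of 9 heavy atoms (7 carbon, 2 nitrogen; one five-membered aromatic ring with 2 hetero atoms, one six-membered aromatic ring of carbon only) in place of a group of 3 heavy atoms (1 carbon, 2 nitrogen; no ring), on an aromatic carbon. Going by the values given here, no measured step is of the same kind: the two steps recorded concern what hangs from the double-bonded nitrogen, not a replacement of that nitrogen group by a fused aromatic ring. The closest guidance is that swapping the 2-aminophenyl for a bare amino moved the number only within the scatter, which suggests the core tolerates a larger arm at this position. It is therefore expected that compound 4 changes by a 1.3-fold lower number from compound 3 to compound 4 (0.12 log units; within the scatter) in this assay, a step of roughly the scatter's size or a little beyond. The estimate for compound 4 in this assay is 100000 nM, with a likely range from 30000 nM to 400000 nM.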

Compound 4, half-maximal inhibitory concentration: 146000 nM
Beside the measured number, compound 4's estimate is 1.5-fold (0.16 log units) below it, and the stated range covers the measured number.
By their numbers in this assay, from the lowest: compounds 3, 4 and 1 (each within the scatter of the next). At a limit, above all of these: compound 2.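

In this assay, the double-bonded nitrogen link is not needed for a value in this range, as compound 4 carries a 1H-benzimidazol-2-yl group directly on the aromatic carbon, with a 1.1-fold higher number from compound 3 to compound 4 (0.05 log units; within the scatter), and the comparison with the other large arm gives a 1.5-fold lower number from compound 1 to compound 4 (0.17 log units; within the scatter). Compounds 1, 3 and 4 therefore sit level with one another despite the different arms, while the hydroxy compound stands apart, with an at least 13-fold lower number from compound 2 to compound 4 (1.13 log units; beyond the scatter). Compound 2 has a limit of the assay and not a number: the limit of > 2000000 nM in this assay, at which 1 of the 4 values shown sits.

None of the arms shown lowers the number beyond the scatter, so it remains open whether any group at this position can do so, and whether the hydrogen on the ring nitrogen of the 1H-benzimidazol-2-yl group matters, which a benzoxazol-2-yl or benzothiazol-2-yl group would test. Also open, on these data alone, is how a plain phenyl group, a carboxylic acid, or a chlorine or methoxy group on the six-membered ring of the 1H-benzimidazol-2-yl group would read in this assay.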